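Swapping a methoxy for a nitro on an aryl amide

The compounds below may be only part of what the source reports. "The series", "measured", "known", "first", "only" and "open" are said of these compounds alone.

Four compounds share the same ethyl ester chain and a small aromatic core; they differ in how the core is joined to a benzoyl group and in the group that sits on the far ring. In a functional assay on the whole organism (strain albino) for inhibition, with Rattus norvegicus as the target, read by paw edema, with stated times of 30 min and 2 h, at a dose of 5 mg/kg by the oral route (a lower number here means less inhibition, a higher number more inhibition at the dose given (going by the name of the read-out)), compound 1 `CCOC(=O)Cc1nc(N)n(C(=O)c2ccc(OC)cc2)n1` gives 41.5%, and compound 2 `CCOC(=O)Cc1nc(N)n(C(=O)c2ccc([N+](=O)[O-])cc2)n1` gives 46.3%. The change between them is nitro in place of methoxy on an aromatic carbon, and the step it made was a number 4.8 percentage points higher from compound 1 to compound 2 (within the scatter).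

Compound 3 `CCOC(=O)Cc1n[nH]c(NC(=O)c2ccc(OC)cc2)n1` has the same atoms as compound 1 joined differently; the difference between the two cores is not broken down here. In this assay compound 3 gives 38.2%, which lies within the usual scatter of the value of compound 1 and also of the value of compound 2.

Compound 4 `CCOC(=O)Cc1n[nH]c(NC(=O)c2ccc([N+](=O)[O-])cc2)n1` has not yet been measured. It stands to compound 3 as compound 2 stands to compound 1: the change is nitro in place of methoxy on an aromatic carbon, made at the same place in words. For the measured compounds named here, with only one earlier example of this change, and that example a step within the scatter, the expectation is that the step from compound 3 to compound 4 will be small as well, estimated as a number 4.8 percentage points higher from compound 3 to compound 4 (within the scatter), because the earlier step of a number 4.8 percentage points higher from compound 1 to compound 2 (within the scatter) was of that size. Compound 4 is therefore expected to give about 43% in this assay, most likely between 30% and 56%.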

Compound 4, a percentage reported as inhibition, in the whole organism at one dose (the size of the read-out at that dose, not a potency): 42.1%
Compound 4: middle estimate off by 0.9 percentage points, on the high side; the measured number falls inside the stated range.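

In this assay, nitro in place of methoxy on the aromatic carbon of the second core gives a number 3.9 percentage points higher from compound 3 to compound 4 (within the scatter). Set beside the same change on the first core, the two steps agree: the same change on two cores in this assay, a number 4.8 percentage points higher (within the scatter) from compound 1 to compound 2 and a number 3.9 percentage points higher (within the scatter) from compound 3 to compound 4, 0.9 percentage points apart, within the scatter of two such steps. This shows that the swap carried across these two cores without a step beyond the scatter on either one; it does not show that nitro truly gives more inhibition than methoxy, since a step within the scatter cannot be told apart from the spread of repeated measurements, and a single pair of small steps on two cores, at one dose, makes no general rule for the series.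

The compounds shown leave open whether a different group on the far ring, such as an amine or a chlorine atom, would give a step beyond the scatter on either core, and whether such a step would then carry from one core to the other. They also leave open how a carboxylic acid in place of the ethyl ester would read in this assay, since the ester chain stays the same in all four compounds.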